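A Bromine for a Methoxy on the Benzyl Ring

The compounds below may be only part of what the source reports. "The series", "measured", "known", "first", "only" and "open" are said of these compounds alone.

Compound 3 `COc1ccc(CN2C(=O)C(=O)c3cc(/C=C/C(=O)N4CCCC4)ccc32)cc1` gives 5230 nM in a functional assay on HT-29 cells (Homo sapiens) for cytotoxicity, read by MTT assay, with a stated time of 48 h (a lower number here means a stronger inhibitor, a higher number a weaker inhibitor), the highest of the three numbers recorded: compound 2 `COc1ccc(CN2C(=O)C(=O)c3cc(/C=C/C(=O)OCCO)ccc32)cc1` gives 550 nM, and compound 1 `COc1ccc(CN2C(=O)C(=O)c3cc(/C=C/C(=O)OC(C)(C)C)ccc32)cc1` gives 480 nM. The steps of a 9.5-fold higher number from compound 2 to compound 3 (0.98 log units; beyond the scatter) and an 11-fold higher number from compound 1 to compound 3 (1.04 log units; beyond the scatter) both concern the substituent on the carbonyl carbon, while a 1.1-fold higher number from compound 1 to compound 2 (0.06 log units; within the scatter) stays within the scatter. Compound 4 `O=C1C(=O)N(Cc2ccc(Br)cc2)c2ccc(/C=C/C(=O)N3CCCC3)cc21` differs from compound 3 in another part of the structure: bromo in place of methoxy on an aromatic carbon. Among the compounds with values here, no measured step touches this part, so nothing recorded argues for a change beyond the scatter. Compound 4 is therefore expected to give about 5000 nM in this assay, between 2000 nM and 13000 nM. The step of a 1.0-fold lower number from compound 3 to compound 4 (0.02 log units; within the scatter) that this estimate implies is expected to be small.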

Compound 4, half-maximal inhibitory concentration: 4420 nM
Beside the measured number, compound 4's estimate is 1.1-fold (0.05 log units) above it; the measured number falls inside the stated range.
By their numbers in this assay, from the lowest: compounds 1 and 2 (each within the scatter of the next); then compounds 4 and 3 (each within the scatter of the next).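

Within the data shown here, the step of a 1.2-fold lower number from compound 3 to compound 4 (0.07 log units; within the scatter) is the first reading of this position on the benzyl ring in this assay. With pyrrolidin-1-yl on the carbonyl carbon, 4-bromobenzyl and 4-methoxybenzyl cannot be told apart here, even though the hydrogen-bond acceptor counted for methoxy is gone. No evidence at hand bears on why the number holds. On these data alone, whether the same exchange holds with tert-butoxy or 2-hydroxyethoxy on the carbonyl carbon remains open. So does what an amine or a carboxylic acid at this position would give.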